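A few compounds are considered here, and "the series" means these few. Any claim that something is new, unique, unknown or untested is made for them only; others in the source may bear on it.

The measured compounds in a functional assay on MCF7 cells (Homo sapiens) for inhibition, read by sulforhodamine B assay, with a stated time of 72 h; on this read-out lower numbers stand for stronger inhibition and higher numbers for weaker inhibition:
compound 1 `O=C(/C=C/c1cn(-c2ccccc2)nc1-c1ccsc1)c1ccccc1` gives 1900 nM;
compound 2 `COc1ccc(C(=O)/C=C/c2cn(-c3ccccc3)nc2-c2ccsc2)c(OC)c1OC` gives 7400 nM;
compound 3 `COc1ccc(C(=O)/C=C/c2cn(-c3ccccc3)nc2-c2ccsc2)c(OC)c1` gives 9000 nM.

Among the three, compound 3 gives the highest number, but a 1.2-fold higher number from compound 2 to compound 3 (0.09 log units; within the scatter) lies within the scatter, so compound 3 and compound 2 cannot be told apart, whereas a 4.7-fold higher number from compound 1 to compound 3 (0.68 log units; beyond the scatter) is beyond it. Compound 4 `COc1ccc(C(=O)/C=C/c2cn(-c3ccccc3)nc2-c2ccncc2)c(OC)c1` differs from compound 3 by pyridin-4-yl in place of thiophen-3-yl on an aromatic carbon. Neither measured step touches this ring: one swaps the aryl on the carbonyl carbon, the other removes a methoxy on an aromatic carbon. Going by the values given here, no measured step therefore bears on this change, and the data give no direction for it. Compound 4 is expected to stay near compound 3, with no change at the digits printed from compound 3 to compound 4 (within the scatter) and a wide range. The estimate for compound 4 in this assay is 9000 nM, between 3000 nM and 27000 nM.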

Compound 4, half-maximal inhibitory concentration: 8800 nM
For compound 4 the middle estimate is 1.0-fold (0.01 log units) above the measured one; low and high end bracket the measured number.
By their numbers in this assay, from the lowest: compound 1; then compounds 2, 4 and 3 (each within the scatter of the next).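

In this assay, going by these compounds alone, pyridin-4-yl in place of thiophen-3-yl gives a 1.0-fold lower number from compound 3 to compound 4 (0.01 log units; within the scatter) and so shows, for the first time at this position, that a six-membered aromatic ring with a nitrogen can stand where a five-membered one with a sulfur stood without a readable change in the number. No measurement at hand offers an explanation for this result.

Going by these compounds, whether the same swap would leave compound 1 unchanged remains open. Also open, on these data alone, is how an amine or a carboxylic acid in place of pyridin-4-yl would read.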